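Trimming a Methyl on the Ester Aryl Group

The source may report more compounds than this note shows. Statements on the series, on what has been measured and on what is new or still open speak of the compounds shown alone.

Compound 3 `Cc1cccc(C(=O)OC(CCN(C)C)c2ccc(Cl)cc2)c1C` sits second highest of the three numbers in an assay on NIH3T3 cells with Urotensin-2 receptor (Homo sapiens) as the target; a higher number here means a larger maximal response, a lower number a smaller maximal response: compound 3 gives 91%, compound 1 `Cc1ccsc1C(=O)OC(CCN(C)C)c1ccc(Cl)cc1` gives 119% and compound 2 `CN(C)CCC(OC(=O)c1ccc(-c2ccccc2)cc1)c1ccc(Cl)cc1` gives 53%. Among the compounds with values here, the one step that touches the same place, a number 28 percentage points lower from compound 1 to compound 3 (beyond the scatter), shows that exchanging the aryl group on the carbonyl carbon can shift this read-out well beyond the scatter. Compound 4 `Cc1ccc(C(=O)OC(CCN(C)C)c2ccc(Cl)cc2)cc1` differs from compound 3 by 4-methylphenyl in place of 2,3-dimethylphenyl on a carbonyl carbon. Within the data shown here, no measured step covers this exact change, so the direction is uncertain; a modest drop seems plausible but is not assured. Compound 4 is therefore expected to show roughly a number 6 percentage points lower from compound 3 to compound 4 (within the scatter), giving an estimated 85% with a range from 55% to 115%.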

Compound 4, largest response reached (reported as efficacy), in percent of the reference or control that the assay uses: 56%
Beside the measured number, compound 4's estimate is 29 percentage points above it; measured number inside the range.
By their numbers in this assay, from the lowest: compounds 2 and 4 (each within the scatter of the next); then compound 3; then compound 1.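

In this assay the choice of aryl group on the carbonyl carbon matters even between two methyl-bearing phenyl groups: 4-methylphenyl replacing 2,3-dimethylphenyl gives a large fall (a number 35 percentage points lower from compound 3 to compound 4 (beyond the scatter)). Against 3-methylthiophen-2-yl the same group also falls far (a number 63 percentage points lower from compound 1 to compound 4 (beyond the scatter)). Methyl and phenyl on the aromatic carbon, by contrast, cannot be told apart (a number 3 percentage points higher from compound 2 to compound 4 (within the scatter)).

No measured evidence accounts for these shifts. As far as these compounds go, what a methoxy group or a fluorine atom in place of that methyl would give remains open.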